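From (4-methylphenyl)amino to pyrrolidin-1-yl on the shared core

The compounds below may be only part of what the source reports. "The series", "measured", "known", "first", "only" and "open" are said of these compounds alone.

Measured in a functional assay on MCF7 cells (Homo sapiens) for inhibition, read by sulforhodamine B assay; a higher number here means a weaker inhibitor, a lower number a stronger inhibitor:
- compound 1 `O=C1C=C(N2CCC2)C(=O)c2c1nc1n2[C@H]2OC[C@@H](O)[C@H]2OC1`: > 16000 nM (a limit)
- compound 2 `Cc1ccc(NC2=CC(=O)c3nc4n(c3C2=O)[C@H]2OC[C@@H](O)[C@H]2OC4)cc1`: 1660 nM

Within the data shown here, compound 2, at 1660 nM, holds the only true number so far. Compound 1 gives only a limit, > 16000 nM.

Compound 3 `O=C1C=C(N2CCCC2)C(=O)c2c1nc1n2[C@H]2OC[C@@H](O)[C@H]2OC1` carries pyrrolidin-1-yl in place of (4-methylphenyl)amino on a double-bonded ring carbon of the shared core: pyrrolidin-1-yl in place of (4-methylphenyl)amino on a double-bonded ring carbon.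

Among the measured compounds shown here, one measured step bears on this change: an at least 9.6-fold lower number from compound 1 to compound 2 (0.98 log units; beyond the scatter), where (4-methylphenyl)amino replaced azetidin-1-yl. One caution applies to that step: the limit of > 16000 nM in this assay, at which 1 of the 2 values shown sits. Its true size may therefore be larger than the number shows. Compound 3, like compound 1, lacks the (4-methylphenyl)amino group and has a non-aromatic ring in that place. A step of similar size towards a higher number in this assay is therefore expected, beyond the scatter, and a reading that is only a limit would not be a surprise.

The expected change is a 6.0-fold higher number from compound 2 to compound 3 (0.78 log units; beyond the scatter). Compound 3 is estimated at 10000 nM, with an expected range of 3500 nM to 30000 nM.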

Compound 3, half-maximal inhibitory concentration: > 16000 nM
Compound 3: only a limit was reported (the forecaster's own chance of this, stated with the estimate: 45%); at least 1.6-fold (0.20 log units) between middle value and limit.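

In this assay, pyrrolidin-1-yl on this double-bonded ring carbon behaves as azetidin-1-yl does, with an at least 9.6-fold higher number from compound 2 to compound 3 (0.98 log units; beyond the scatter). Of the three groups shown at this place, only (4-methylphenyl)amino gives a true number, and both single-place comparisons with it point the same way, with no compound in the series going against them. The printed step size is a floor, and the step between the two non-aromatic rings, from compound 1 to compound 3, cannot be read, because both compounds sit at the limit: the limit of > 16000 nM in this assay, at which 2 of the 3 values shown sit.

The change from (4-methylphenyl)amino to pyrrolidin-1-yl removes the aromatic ring and the hydrogen-bond donor together, so the data do not say which of the two goes with the lower number; N-methyl-(4-methylphenyl)amino and cyclohexylamino would separate them. As far as these compounds go, the part played by the methyl group also stays open, and plain phenylamino or (4-methoxyphenyl)amino on the shared core would address it.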